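Cyclohexylmethyl to cyclobutyl on the ring nitrogen

The compounds below may be only part of what the source reports. "The series", "measured", "known", "first", "only" and "open" are said of these compounds alone.

Within the data shown here, compound 1 `N#Cc1cnc(NCc2cnccc2C(F)(F)F)cc1NC[C@H]1CC[C@H](O)CC1` is the weaker of the two compounds measured so far in an assay on isolated protein for inhibition of protein kinase C theta type (Homo sapiens), read by TR-FRET, with a stated time of 2 h; on this read-out higher numbers stand for weaker inhibition and lower numbers for stronger inhibition. In this assay compound 1 gives 50 nM, while compound 2 `N#Cc1cnc(NCc2ccccc2C(F)(F)F)cc1N[C@H]1CC[C@@H](C(N)=O)CC1` gives 20 nM, a gap wide enough to sit beyond the usual scatter. Compound 3 `CC1(C)[C@@H](C(N)=O)C[C@H]1Nc1cc(NCc2cnccc2C(F)(F)F)ncc1C#N` has not yet been measured. It differs from compound 1 in one place: 3-carbamoyl-2,2-dimethylcyclobutyl in place of (4-hydroxycyclohexyl)methyl on a nitrogen on an aromatic ring. Compound 2 also carries a carbamoyl group on a ring joined straight to the aromatic nitrogen, and its value of 20 nM in this assay is the better of the two. On that showing, compound 3 is expected to land at 30 nM, most likely between 10 nM and 100 nM. The expected step of a 1.7-fold lower number from compound 1 to compound 3 (0.22 log units; within the scatter) is a small gain, near the edge of the scatter rather than far beyond it.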

Compound 3, half-maximal inhibitory concentration: 1.4 nM
The estimate for compound 3 lay 21-fold (1.33 log units) above the measured number; measured number below the stated range.
By their numbers in this assay, from the lowest: compound 3; then compound 2; then compound 1.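

In this assay, the group on the nitrogen on the aromatic ring proves to be a strong lever: with the rest of the molecule unchanged, 3-carbamoyl-2,2-dimethylcyclobutyl in place of (4-hydroxycyclohexyl)methyl gives a 36-fold lower number from compound 1 to compound 3 (1.55 log units; beyond the scatter). The earlier pair differed in more than one place and could not isolate this position, whereas this pair does; the two groups also have equal counts of hydrogen-bond donors and acceptors, so those counts do not track the difference.

The compounds shown leave open which part of the change carries the gain, since the ring size, the carbamoyl group and the two methyl groups all change together. As far as these compounds go, how a carboxylic acid in place of the carbamoyl group on the same cyclobutyl would read also remains open. Nothing at hand explains the size of this gain.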